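Trimming the side chain of compound 1

The source may hold more compounds than are shown below. What is called first, only, known or untested is meant among the compounds shown, and "the series" means these compounds.

Measured so far:
compound 1 `CCCC1=C(OCCC(C)C)C(CCC)(CCC)C(=O)/C(=C(O)\C=C\c2ccccc2)C1=O` — 17 uM
compound 2 `CCCC1=C(OC)C(CCC)(CCC)C(=O)/C(=C(O)\C=C\c2ccc(Br)cc2)C1=O` — 4.7 uM

In a functional assay on PC-3 cells (Homo sapiens) for antiproliferative activity, read by sulforhodamine B assay, with a stated time of 3 days (on this read-out higher numbers stand for an effect only at larger amounts of compound and lower numbers for an effect already at smaller amounts), compound 1 gives 17 uM, the highest of the two numbers in hand. In this assay compound 2 gives 4.7 uM; the gap between the two lies beyond the usual scatter, but compound 2 differs from compound 1 in two places at once, so no single change can be read from that pair.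

Compound 3 `CCCOC1=C(CCC)C(=O)/C(=C(O)/C=C/c2ccccc2)C(=O)C1(CCC)CCC` is the next one to go into this assay. It differs from compound 1 by methyl in place of isopropyl on a saturated chain carbon, two bonds along the chain from an oxygen on an unsaturated carbon. For the measured compounds named here, no measured pair isolates this change. Compound 2, which carries a shorter chain at the same position together with its second change, gives 4.7 uM, which leaves open a modest move toward lower numbers. The expected step of a 1.4-fold lower number from compound 1 to compound 3 (0.15 log units; within the scatter) is estimated as small, at most at the edge of the scatter. Compound 3 is therefore expected near 12 uM, with a range from 5 uM to 30 uM.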

Compound 3, concentration for half-maximal effect: 8.6 uM
The estimate for compound 3 lay 1.4-fold (0.14 log units) above the measured number; measured number inside the range.
By their numbers in this assay, from the lowest: compounds 2, 3 and 1 (each within the scatter of the next, the first and the last beyond it).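

For the compounds shown here, this is the first comparison at this position that changes one place only: isopentyloxy gives way to propoxy, and this assay reads a 2.0-fold lower number from compound 1 to compound 3 (0.30 log units; within the scatter). The two chains are therefore not told apart here, and the position accepts the propoxy chain, without its isopropyl end, with no step beyond the scatter. No further measurement on hand bears on this result.

As far as these compounds go, compound 2 carries a shorter chain at this position together with a second change, so the effect of that shorter chain alone stays open. Also open, from the compounds shown here alone, is what a longer chain, or an amine or a carboxylic acid carried on the propoxy chain, would give at this position.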